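The source may hold more compounds than are shown below. What is called first, only, known or untested is meant among the compounds shown, and "the series" means these compounds.

Measured so far in a functional assay on T47D cells (Homo sapiens) for inhibition, read by sulforhodamine B assay, with a stated time of 48 h, tested at 10 uM; on this read-out lower numbers stand for less inhibition and higher numbers for more inhibition at the one concentration tested (going by the name of the read-out):
- compound 1, `Brc1cn2ccnc2c(-c2ccc3ncn(C4CCCCC4)c3c2)n1`: 49.7%
- compound 2, `c1ccc(-c2cn3ccnc3c(-c3ccc4ncn(C5CCCCC5)c4c3)n2)cc1`: -11.1%
- compound 3, `CC(=O)c1ccc(-c2cn3ccnc3c(-c3ccc4ncn(C5CCCCC5)c4c3)n2)cc1`: 54.4%

Compound 3 has the highest of the three numbers in this assay. Its nearest neighbour is compound 1, whose number lies within the scatter of it (a number 4.7 percentage points higher from compound 1 to compound 3 (within the scatter)), so the two cannot be ordered. Compound 2 lies far below both: a number 60.8 percentage points lower from compound 1 to compound 2 (beyond the scatter) and a number 65.5 percentage points higher from compound 2 to compound 3 (beyond the scatter).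

The next compound, compound 4, `COc1ccccc1-c1cn2ccnc2c(-c2ccc3ncn(C4CCCCC4)c3c2)n1`, carries the change (2-methoxyphenyl in place of 4-acetylphenyl on an aromatic carbon). For the measured compounds named here, two measured steps bear on it. The step from phenyl to 4-acetylphenyl, seen as a number 65.5 percentage points higher from compound 2 to compound 3 (beyond the scatter), shows that a bare phenyl at this position gives essentially no inhibition, while a substituted phenyl recovers it. Going by the values given here, compound 4 keeps a substituted phenyl, but the substituent and its position on the ring differ from those of compound 3, and no measured compound tells whether a 2-methoxyphenyl behaves like 4-acetylphenyl or like phenyl. Given that compound 2 sits so far down, a drop from compound 3 is expected, of uncertain size and possibly beyond the scatter: a number 34.4 percentage points lower from compound 3 to compound 4 (beyond the scatter).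

Compound 4 is therefore estimated at 20% in this assay, with an expected range from -15% to 55%.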

Compound 4, a percentage reported as inhibition, at one concentration (the size of the read-out at that concentration, not a potency): 36.6%
Beside the measured number, compound 4's estimate is 16.6 percentage points below it; low and high end bracket the measured number.
By their numbers in this assay, from the lowest: compound 2; then compound 4; then compounds 1 and 3 (each within the scatter of the next).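

In this assay, a second substituted phenyl at this position also stands well clear of the bare phenyl (a number 47.7 percentage points higher from compound 2 to compound 4 (beyond the scatter)), so the near absence of inhibition seen with phenyl is no longer set against 4-acetylphenyl alone. The recovery varies with the group, however: 2-methoxyphenyl falls short of 4-acetylphenyl (a number 17.8 percentage points lower from compound 3 to compound 4 (beyond the scatter)) and also of bromo (a number 13.1 percentage points lower from compound 1 to compound 4 (beyond the scatter)), so a substituted phenyl does not guarantee a return to the level shared by compound 1 and compound 3, which could not be ordered. Nothing available here explains the size of these steps.

From the compounds shown here alone, compound 3 and compound 4 differ both in the substituent and in its place on the ring, so it remains open whether the gap between them follows the acetyl and methoxy groups themselves or where they sit. Also open, going by these compounds, is where a phenyl carrying an amine or a carboxylic acid would fall in this range, and whether a longer alkyl chain could take the place of the ring at this position.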